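Methyl to fluoro on the fused ring, second instance

A few compounds are considered here, and "the series" means these few. Any claim that something is new, unique, unknown or untested is made for them only; others in the source may bear on it.

Compound 1 `COc1cc(-c2nc3ccc(C)cn3c2NC2CCCCC2)ccc1OCCCNC(=O)Nc1ccc(OC(F)(F)F)cc1` gives 116 nM in an assay for inhibition of Polyunsaturated fatty acid 5-lipoxygenase (Homo sapiens), read by HPLC, with a stated time of 15 min; on this read-out lower numbers stand for stronger inhibition and higher numbers for weaker inhibition. Compound 2 `COc1cc(-c2nc3ccc(F)cn3c2NC2CCCCC2)ccc1OCCCNC(=O)Nc1ccc(OC(F)(F)F)cc1` differs from it by fluoro in place of methyl on an aromatic carbon and gives 696 nM in this assay; that change made a 6.0-fold higher number from compound 1 to compound 2 (0.78 log units; beyond the scatter). Compound 3 `COc1cc(-c2nc3ccc(C)cn3c2NC2CCCC2)ccc1OCCCNC(=O)Nc1ccc(C(F)(F)F)cc1` gives 614 nM in this assay; the difference between its core and the core of compound 1 is not broken down here. Compound 4 `COc1cc(-c2nc3ccc(F)cn3c2NC2CCCC2)ccc1OCCCNC(=O)Nc1ccc(C(F)(F)F)cc1` is not yet measured and differs from compound 3 by fluoro in place of methyl on an aromatic carbon, the same change at the same place as between compound 1 and compound 2. Among the compounds with values here, a step of similar size is expected, a 4.9-fold higher number from compound 3 to compound 4 (0.69 log units; beyond the scatter) in this assay, because the single earlier instance of this change gave a 6.0-fold higher number from compound 1 to compound 2 (0.78 log units; beyond the scatter); with only one precedent, the range is kept wide. Compound 4 is estimated at 3000 nM, between 1000 nM and 9000 nM.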

Compound 4, half-maximal inhibitory concentration: 480 nM
Compound 4: middle estimate off by 6.3-fold (0.80 log units), on the high side; the measured number lies below the stated range.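

On the core of compound 3 in this assay, fluoro in place of methyl gives a 1.3-fold lower number from compound 3 to compound 4 (0.11 log units; within the scatter), so no shift can be claimed on that core. Set beside the earlier instance, the change does not behave as a fixed step across the two cores: the same change on two cores in this assay, a 6.0-fold higher number (0.78 log units; beyond the scatter) from compound 1 to compound 2 and a 1.3-fold lower number (0.11 log units; within the scatter) from compound 3 to compound 4, 7.7-fold (0.89 log units) apart, beyond the scatter of two such steps

The size of the step on one core therefore cannot be carried over to another in this series, but these two pairs do not show which of the differences between the two cores goes with the gap. The compounds shown leave open how the change behaves on cores that differ from these in one place only. They also leave open whether a chloro or nitrile group on the same aromatic carbon would track with fluoro or with methyl.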